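A few compounds are considered here, and "the series" means these few. Any claim that something is new, unique, unknown or untested is made for them only; others in the source may bear on it.

Compound 3 `COc1cc(N2C(=O)[C@@H](Oc3ccccc3)[C@H]2c2ccc([N+](=O)[O-])cc2)cc(OC)c1OC` sits at the high end of a small set of three azetidinone analogues sharing one core. In a functional assay on MCF7 cells (Homo sapiens) for antiproliferative activity, read by MTT assay, with stated times of 24 h and 72 h (on this read-out lower numbers stand for stronger inhibition and higher numbers for weaker inhibition), compound 3 gives 63000 nM, compound 2 `COc1cc(N2C(=O)[C@@H](Oc3ccccc3)[C@H]2c2ccc(Br)cc2)cc(OC)c1OC` gives 48000 nM, and compound 1 `COc1cc([C@@H]2[C@H](Oc3ccccc3)C(=O)N2c2cc(OC)c(OC)c(OC)c2)cc(OC)c1OC` gives 29000 nM. Among the compounds with values here, the steps that bear on the aryl group on the saturated ring carbon were a 2.2-fold higher number from compound 1 to compound 3 (0.34 log units; beyond the scatter) and a 1.7-fold higher number from compound 1 to compound 2 (0.22 log units; within the scatter), while a 1.3-fold higher number from compound 2 to compound 3 (0.12 log units; within the scatter). Compound 4 `COc1cc(N2C(=O)[C@@H](Oc3ccccc3)[C@H]2c2cc(O)c(OC)c([N+](=O)[O-])c2)cc(OC)c1OC` differs from compound 3 by a group of 12 heavy atoms (7 carbon, 1 nitrogen, 4 oxygen; one six-membered aromatic ring of carbon only) in place of a group of 9 heavy atoms (6 carbon, 1 nitrogen, 2 oxygen; one six-membered aromatic ring of carbon only), on a saturated ring carbon. Since compound 1 carries the most oxygenated aryl group and gives 29000 nM, a modest move toward lower numbers is expected, a 1.6-fold lower number from compound 3 to compound 4 (0.20 log units; within the scatter). Compound 4 is therefore estimated at 40000 nM in this assay, with a range of 15000 nM to 100000 nM.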

Compound 4, half-maximal inhibitory concentration: 69000 nM
Estimate against measurement, compound 4: 1.7-fold (0.24 log units) below; the range from low to high includes it.
By their numbers in this assay, from the lowest: compounds 1, 2, 3 and 4 (each within the scatter of the next, the first and the last beyond it).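

In this assay, the group of compound 4 brings a hydrogen-bond donor that 4-nitrophenyl lacks, yet the number stays level with its neighbours: a 1.1-fold higher number from compound 3 to compound 4 (0.04 log units; within the scatter) and a 1.4-fold higher number from compound 2 to compound 4 (0.16 log units; within the scatter). Only the comparison with 3,4,5-trimethoxyphenyl stands out, a 2.4-fold higher number from compound 1 to compound 4 (0.38 log units; beyond the scatter), so an equal count of heavy atoms at this saturated ring carbon does not reproduce the number of compound 1. Nothing measured here explains this result. The compounds shown leave open whether an amine or a carboxylic acid on this aryl group would give a lower number, and whether a longer chain could replace the aryl group.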